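The source may report more compounds than this note shows. Statements on the series, on what has been measured and on what is new or still open speak of the compounds shown alone.

Three compounds share one core. Among the measured compounds shown here, in a functional assay on K562 cells (Homo sapiens) for inhibition (a higher number here means a weaker inhibitor, a lower number a stronger inhibitor), compound 2 `CN(C)CCNC(=O)c1nc(NC(=O)c2nc(NC(=O)CBr)cn2C)cn1C` gives 400000 nM and is the only one with a number. Compound 1 `CN(C)CCNC(=O)c1nc(NC(=O)c2nc(NC=O)cn2C)cn1C` stands at a limit of the assay, > 500000 nM. Compound 3 `CN(C)CCNC(=O)c1nc(NC(=O)c2nc(NC(=O)C(Cl)Cl)cn2C)cn1C` also stands at a limit, > 500000 nM. Two of the three values thus sit at the limit of > 500000 nM in this assay, at which 2 of the 3 values shown sit. Compound 4 `CN(C)CCNC(=O)c1nc(NC(=O)c2nc(NC(=O)C3CC3)cn2C)cn1C` differs from compound 2 by cyclopropyl in place of bromomethyl on a carbonyl carbon. For the measured compounds named here, the steps that bear on this change are an at least 1.2-fold lower number from compound 1 to compound 2 (0.09 log units; that floor lies within the scatter) and an at least 1.2-fold higher number from compound 2 to compound 3 (0.09 log units; that floor lies within the scatter), while a step that the two limits leave unreadable from compound 1 to compound 3. Neither measured step leaves the scatter, so no step beyond the scatter is expected in this assay for compound 4. Compound 4 is therefore estimated at 450000 nM, between 200000 nM and 1000000 nM. That estimate means an expected step of a 1.1-fold higher number from compound 2 to compound 4 (0.05 log units; within the scatter).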

Compound 4, half-maximal inhibitory concentration: > 500000 nM
Compound 4: no number, only a limit; the forecaster's own chance of this, stated with the estimate: 60%; at least 1.1-fold (0.04 log units) between middle value and limit.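

In this assay, cyclopropyl in place of bromomethyl on the carbonyl carbon gives an at least 1.2-fold higher number from compound 2 to compound 4 (0.09 log units; that floor lies within the scatter). Compound 4 stands at a limit of the assay, so cyclopropyl, the first ring at this place, gives no readable number, and the steps to compound 4 from compound 1 and from compound 3 cannot be read. The series now rests largely on one limit: the limit of > 500000 nM in this assay, at which 3 of the 4 values shown sit.

Going by these compounds, whether an amine or a longer chain on this carbonyl carbon would give a number clear of that limit stays open. On these data alone, how far compound 1, compound 3 and compound 4 lie beyond it also stays open.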